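Hydroxymethyl in Place of Cyano: What to Expect for Compound 4

This account rests on a few compounds, and the source may have more. Where it says the series, first, only, none or still open, it means among the compounds named here.

Compound 1, `O=C(Nc1ccnnc1)c1cc(N2CCC(F)CC2)ccc1OCc1ccccc1`, gives 39.8 nM in an assay on Sf9 cells for inhibition of Leucine-rich repeat serine/threonine-protein kinase 2 (Homo sapiens), read by TR-FRET, with stated times of 30 min and 2 h; on this read-out lower numbers stand for stronger inhibition and higher numbers for weaker inhibition.
Compound 2, `CN1CCN(c2ccc(OCc3ccccc3)c(C(=O)Nc3ccnnc3)c2)CC1`, gives 12.6 nM in this assay.
Compound 3, `N#CC1CCN(c2ccc(OCc3ccccc3)c(C(=O)Nc3ccnnc3)c2)CC1`, gives 10 nM in this assay.

Compound 3 has the lowest number of the three. Its gap to compound 2, a 1.3-fold lower number from compound 2 to compound 3 (0.10 log units; within the scatter), lies within the scatter, so these two cannot be placed in order. Compound 1 sits clearly apart: a 4.0-fold lower number from compound 1 to compound 3 (0.60 log units; beyond the scatter).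

Compound 4, `O=C(Nc1ccnnc1)c1cc(N2CCC(CO)CC2)ccc1OCc1ccccc1`, differs from compound 3 in one place: hydroxymethyl in place of cyano on a saturated ring carbon. Two earlier steps bear on this. The change at the same saturated ring carbon, a 4.0-fold lower number from compound 1 to compound 3 (0.60 log units; beyond the scatter), was modest. Exchanging the whole ring substituent, a 1.3-fold lower number from compound 2 to compound 3 (0.10 log units; within the scatter), stayed within the scatter. Across the three compounds the group on this ring has therefore moved the numbers only modestly at most, and all three sit in a narrow band.

The expectation for compound 4 is accordingly a small step, if any, with the number drifting a little upward: a 1.6-fold higher number from compound 3 to compound 4 (0.20 log units; within the scatter). Compound 4 is estimated at 16 nM in this assay, with a range from 5 nM to 50 nM.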

Compound 4, half-maximal inhibitory concentration in the Leucine-rich repeat serine/threonine-protein kinase 2 assay: 20 nM
Compound 4: the middle estimate sits 1.3-fold (0.10 log units) below what was measured; the range from low to high includes it.
By their numbers in the Leucine-rich repeat serine/threonine-protein kinase 2 assay, from the lowest: compounds 3, 2, 4 and 1 (each within the scatter of the next, the first and the last beyond it).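

In the Leucine-rich repeat serine/threonine-protein kinase 2 assay, hydroxymethyl, which carries a hydrogen-bond donor where cyano has none, fits on this saturated ring carbon without a step that can be read as a change: a 2.0-fold higher number from compound 3 to compound 4 (0.30 log units; within the scatter), a 1.6-fold higher number from compound 2 to compound 4 (0.20 log units; within the scatter) and a 2.0-fold lower number from compound 1 to compound 4 (0.30 log units; within the scatter), so compound 4 cannot be placed in order against any of the other three. For compound 3, the value in a physicochemical assay for solubility, measured as kinetic solubility (a higher number here means a more soluble compound, a lower number a less soluble compound), < 1000 nM, is a limit of the assay and not a number. In the physicochemical assay compound 4 gives 323000 nM. The same small exchange, which leaves the inhibition numbers within the scatter, comes with a large difference in the physicochemical assay, something the earlier inhibition numbers alone could not show: the measured solubility of compound 3, < 1000 nM, and of compound 4, 323000 nM, an at least 320-fold higher number (2.50 log units; beyond the scatter)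

From the compounds shown here alone, whether this separation of inhibition and solubility belongs to hydroxymethyl alone stays open, and an aminomethyl group, a carboxylic acid or a longer chain such as hydroxyethyl on the same ring carbon would test it. Going by these compounds, the values shown give solubility for compound 3 and compound 4 only, so how solubility follows the group on this ring across the wider series also remains open.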